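Dichlorobenzyl change on the compound 1 series

The source may hold more compounds than are shown below. What is called first, only, known or untested is meant among the compounds shown, and "the series" means these compounds.

Measured in a functional assay on HT-29 cells (Homo sapiens) for cytotoxicity, read by MTT assay, with a stated time of 48 h; on this read-out higher numbers stand for weaker inhibition and lower numbers for stronger inhibition:
- compound 1 `COC(=O)/C=C/c1ccc2c(c1)C(=O)C(=O)N2Cc1ccccc1` gives 70 nM
- compound 2 `COC(=O)/C=C/c1ccc2c(c1)C(=O)C(=O)N2` gives 270 nM
- compound 3 `COC(=O)/C=C/c1ccc2c(c1)C(=O)C(=O)N2Cc1ccc2ccccc2c1` gives 100 nM

Compound 1 shares the low end of these numbers with compound 3, their values lying within the scatter of each other, while compound 2 stands apart. The change to compound 4 `COC(=O)/C=C/c1ccc2c(c1)C(=O)C(=O)N2Cc1ccc(Cl)c(Cl)c1` is 3,4-dichlorophenyl in place of phenyl on a saturated chain carbon bound to an amide-type nitrogen in a ring, with 3,4-dichlorophenyl in place of phenyl on a saturated chain carbon bound to an amide-type nitrogen in a ring. Going by the values given here, the one measured step at this nitrogen is a 3.9-fold higher number from compound 1 to compound 2 (0.59 log units; beyond the scatter), which removes the benzyl entirely and so bears only loosely. Among the compounds with values here, no measured step adds groups to the phenyl. Compound 3 carries another group on the same chain carbon and gives 100 nM, close to compound 1. From the compounds shown here alone, no step beyond the scatter is therefore expected in this assay, and the direction stays open. The estimated step is a 1.2-fold lower number from compound 1 to compound 4 (0.07 log units; within the scatter). Compound 4 is expected at 60 nM, within an estimated range of 25 nM to 150 nM.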

Compound 4, half-maximal inhibitory concentration: 210 nM
Beside the measured number, compound 4's estimate is 3.5-fold (0.54 log units) below it; the whole stated range lies below it.
By their numbers in this assay, from the lowest: compounds 1 and 3 (each within the scatter of the next); then compounds 4 and 2 (each within the scatter of the next).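

Substitution on the phenyl is not neutral at this position: a 3.0-fold higher number from compound 1 to compound 4 (0.48 log units; beyond the scatter) in this assay follows from 3,4-dichlorophenyl in place of phenyl. Compound 4 at 210 nM lies within the scatter of compound 2 at 270 nM and thus the difference seen in a 3.9-fold higher number from compound 1 to compound 2 (0.59 log units; beyond the scatter) is not retained with this group. No available evidence bears on the reason for this loss. From the compounds shown here alone, whether a single chlorine on the phenyl gives the same loss stays open, as does the outcome with a methoxy group or an amine there.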